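A few compounds are considered here, and "the series" means these few. Any claim that something is new, unique, unknown or untested is made for them only; others in the source may bear on it.

Measured so far:
- compound 1 `Nc1scc(CN2CCN(c3ccccc3F)CC2)c1C(=O)c1ccc(Cl)cc1`: -15%
- compound 2 `Nc1scc(CN2CCN(c3cc(F)ccc3F)CC2)c1C(=O)c1ccc(Cl)cc1`: -80%

In a functional assay on CHO cells with adenosine receptor A1 (Homo sapiens) as the target, read by cAMP accumulation and immunoassay, with a stated time of 6 min, tested at 10 uM (on this read-out lower numbers stand for a stronger effect and higher numbers for a weaker effect at the one concentration tested), compound 2 gives the lowest of the two numbers; its nearest neighbour is compound 1, and the step of a number 65 percentage points lower from compound 1 to compound 2 (beyond the scatter) is beyond the scatter and large.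

Compound 3 `Nc1scc(CN2CCN(c3ccccc3Cl)CC2)c1C(=O)c1ccc(Cl)cc1` is not yet measured. It differs from compound 2 by 2-chlorophenyl in place of 2,5-difluorophenyl on an amine nitrogen in a ring.

Within the data shown here, the only measured step in this assay, a number 65 percentage points lower from compound 1 to compound 2 (beyond the scatter), concerns the fluoro that compound 3 lacks; compound 3 keeps a single halogen on the phenyl, as compound 1 does, but with chlorine in place of fluorine, a change for which no measured step exists. The expectation is therefore that compound 3 moves back toward compound 1, by the step of a number 45 percentage points higher from compound 2 to compound 3 (beyond the scatter), with wide uncertainty.

Compound 3 is estimated at -35%, in the range -75% to 5%.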

Compound 3, a percentage reported as activity, at one concentration (the size of the read-out at that concentration, not a potency): -18%
Estimate against measurement, compound 3: 17 percentage points below; measured number inside the range.
By their numbers in this assay, from the lowest: compound 2; then compounds 3 and 1 (each within the scatter of the next).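

In this assay there is a number 62 percentage points higher from compound 2 to compound 3 (beyond the scatter), so the low number of compound 2 does not carry over to 2-chlorophenyl on this amine nitrogen in the ring. With a number 3 percentage points lower from compound 1 to compound 3 (within the scatter), chloro and fluoro on an otherwise unsubstituted phenyl cannot be told apart here, and among these three compounds only the 2,5-difluorophenyl of compound 2 stands apart. Nothing available explains this difference.

The compounds shown leave open whether a 2,5-dichlorophenyl would follow compound 2 or stay with compound 3, which would show whether the second halogen matters or only a second fluoro does. Also open, on these data alone, is how a plain phenyl, or a methyl or methoxy group in place of the halogen, would read at this place.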